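The source may report more compounds than this note shows. Statements on the series, on what has been measured and on what is new or still open speak of the compounds shown alone.

Measured so far in a toxicity assay on the whole organism (strain Icem-CET (SPF Caw)) for cytotoxicity, with Mus musculus as the target; a higher number here means that more compound is needed for the effect, a lower number that less compound is needed:
compound 1, `COc1ccc(/C(C)=C(/C)C(=O)NC2CC2)cc1` — 300 mg/kg
compound 2, `C=CCNC(=O)/C(C)=C(\C)c1ccc(OC)cc1` — 200 mg/kg

Compound 2 stands at the low end of the two numbers in this assay; compound 1 lies beside it, and the gap between them is within the scatter, so the two are not separated by the data. Among the measured compounds shown here, both share the same core and the same methoxyphenyl-bearing double bond; they differ in the amide substituent only, and no step between them is counted here.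

The next compound, compound 3, `C=CCNC(=O)/C(C)=C(/C)c1ccc(OC)cc1`, keeps the allyl amide of compound 2 and changes nothing in its atoms or bonds: the two compounds have the same atoms and bonds and differ only in configuration as drawn: 1 of 1 stereo elements differ; a double bond is drawn E in compound 2 and Z in compound 3. For the measured compounds named here, a change of geometry alone, with no group leaving or entering, has no counterpart among the measured pair, so nothing in the data points to a direction. The expectation is therefore a step from compound 2 to compound 3 of no change at the digits printed from compound 2 to compound 3 (within the scatter), that is, none beyond the scatter in either direction. Compound 3 in this assay is estimated at 200 mg/kg, with a range from 100 mg/kg to 400 mg/kg.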

Compound 3, dose for half-maximal effect: 280 mg/kg
Beside the measured number, compound 3's estimate is 1.4-fold (0.15 log units) below it, within the range that was stated.
By their numbers in this assay, from the lowest: compounds 2, 3 and 1 (each within the scatter of the next).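

Until now the series offered no comparison at this double bond. In this assay, the E to Z change on the allyl amide gives a 1.4-fold higher number from compound 2 to compound 3 (0.15 log units; within the scatter), so at this position geometry alone does not separate the two compounds in this assay, and this pair has only one variable to weigh: the fact that compounds 2 and 3 differ only in the configuration as drawn

Among the compounds shown here, the same Z geometry also allows the first readable comparison on the amide nitrogen, where allyl in place of cyclopropyl gives a 1.1-fold lower number from compound 1 to compound 3 (0.03 log units; within the scatter). With both steps inside the scatter, neither change moves the dose needed in this assay by a measurable amount, and the three compounds form one band with no order among them.

Still open, on these data alone, is whether anything on the amide nitrogen other than allyl and cyclopropyl, such as a longer alkyl chain, a carboxylic acid or an amine, would give a step beyond the scatter. The compounds shown also leave open whether replacing the methoxy group on the aromatic ring with a hydroxyl or a halogen such as chlorine would shift the number in this assay.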